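Lengthening the heptyl chain of compound 3

The source may hold more compounds than are shown below. What is called first, only, known or untested is meant among the compounds shown, and "the series" means these compounds.

Compound 1 `CCCCCOc1ccc(-c2c(C)[nH]c(=O)n2C2CCCCC2)cc1`: 9100 nM
Compound 2 `Cc1[nH]c(=O)n(C2CCCCC2)c1-c1ccc(OCCC(C)C)cc1`: 7200 nM
Compound 3 `CCCCCCCc1ccc(-c2c(C)[nH]c(=O)n2C2CCCCC2)cc1`: 8700 nM
Compound 4 `CCCCCCCCc1ccc(-c2c(C)[nH]c(=O)n2C2CCCCC2)cc1`: not yet measured

In a functional assay on brain (Rattus norvegicus, strain Wistar) for inhibition (a lower number here means a stronger inhibitor, a higher number a weaker inhibitor), compound 3 gives 8700 nM, level with the other two compounds within the scatter. The comparisons show a 1.0-fold lower number from compound 1 to compound 3 (0.02 log units; within the scatter) and a 1.2-fold higher number from compound 2 to compound 3 (0.08 log units; within the scatter). The change leading to compound 4 is methyl in place of hydrogen on a saturated chain carbon, seven bonds along the chain from an aromatic carbon. Going by the values given here, no measured step makes exactly this change. The nearest evidence comes from steps that also alter the chain, namely a 1.0-fold lower number from compound 1 to compound 3 (0.02 log units; within the scatter) and a 1.3-fold lower number from compound 1 to compound 2 (0.10 log units; within the scatter). Going by these compounds, both stay within the scatter, so no shift beyond the scatter is expected in this assay, and the direction remains open. The estimated step is a 1.2-fold lower number from compound 3 to compound 4 (0.06 log units; within the scatter). For compound 4 the expected value is 7500 nM, with an estimated range from 3500 nM to 14000 nM.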

Compound 4, half-maximal inhibitory concentration: 10300 nM
Beside the measured number, compound 4's estimate is 1.4-fold (0.14 log units) below it; measured number inside the range.
By their numbers in this assay, from the lowest: compounds 2, 3, 1 and 4 (each within the scatter of the next).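

In this assay, methyl in place of hydrogen on a saturated chain carbon, seven bonds along the chain from an aromatic carbon, gives a 1.2-fold higher number from compound 3 to compound 4 (0.07 log units; within the scatter), so one more carbon on the heptyl chain leaves the number level. Octyl in place of isopentyloxy gives a 1.4-fold higher number from compound 2 to compound 4 (0.16 log units; within the scatter) and octyl in place of pentyloxy gives a 1.1-fold higher number from compound 1 to compound 4 (0.05 log units; within the scatter), so the octyl chain also stays level with both oxygen-linked chains. No further measurement bears on this result. Going by these compounds, whether a longer chain, or an amine or carboxylic acid on the chain, would move the number beyond the scatter remains open.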